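Swapping Isobutyl for Sec-Butyl on an Amine Nitrogen

The compounds below may be only part of what the source reports. "The series", "measured", "known", "first", "only" and "open" are said of these compounds alone.

Among the compounds with values here, in a functional assay on CHO-K1 cells (Cricetulus griseus) for inhibition, read by MTT assay, with a stated time of 72 h (on this read-out higher numbers stand for weaker inhibition and lower numbers for stronger inhibition), compound 1 `CC(C)CNC(=C\C(=O)/C=C/c1ccc(O)cc1)/C=C/c1ccc(O)cc1` gives 17900 nM, the only true number among the three compounds measured so far. Compound 2 `COc1cc(/C=C/C(=O)/C=C(/C=C/c2ccc(OC(C)=O)c(OC)c2)NCC(C)C)ccc1OC(C)=O` reads > 25000 nM, which is a limit and not a number. Compound 3 `COc1cc(/C=C/C(=O)CC(=O)/C=C/c2ccc(OC(C)=O)c(OC)c2)ccc1OC(C)=O` reads > 25000 nM, which is also a limit. The data are thus dominated by the limit of > 25000 nM in this assay, at which 2 of the 3 values shown sit, and compound 1 has no measured neighbour to be compared with directly.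

The next compound to be tested is compound 4 `CCC(C)NC(=C\C(=O)/C=C/c1ccc(O)cc1)/C=C/c1ccc(O)cc1`, which has sec-butyl in place of isobutyl on an amine nitrogen. The two compounds have the same atoms, joined differently. Within the data shown here, no measured pair gauges such a change, so no shift beyond the usual scatter of this assay is expected in either direction. That expectation rests on compound 1 alone, at 17900 nM. The expected result is a 1.0-fold higher number from compound 1 to compound 4 (0.00 log units; within the scatter). For compound 4 the estimated value is 18000 nM, with an expected range of 9000 nM to 32000 nM.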

Compound 4, half-maximal inhibitory concentration: 13100 nM
For compound 4 the middle estimate is 1.4-fold (0.14 log units) above the measured one, within the range that was stated.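

In this assay, replacing isobutyl with sec-butyl on an amine nitrogen gives a 1.4-fold lower number from compound 1 to compound 4 (0.14 log units; within the scatter). Within the data shown here, this is the first step read at this position, and on this read-out the two butyl groups are not told apart. Like compound 1, compound 4 gives a true number and not a limit, so this pair can be read directly, which much of the set cannot: the limit of > 25000 nM in this assay, at which 2 of the 4 values shown sit.

Going by these compounds, whether a longer chain such as n-octyl, or a benzyl group, on this nitrogen would move the number beyond the scatter remains open. Also open, on these data alone, is whether the same swap would read alike on the core of compound 2, whose value is only a limit.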